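Adding a Methoxy Group to a Sulfonamide Benzoxazole

The compounds below may be only part of what the source reports. "The series", "measured", "known", "first", "only" and "open" are said of these compounds alone.

Compound 1, `O=S(=O)(Nc1ccc(-c2nc3ccccc3o2)cc1)c1cccc(Cl)c1`. In an assay on isolated protein for inhibition of malate dehydrogenase, mitochondrial (Sus scrofa), with stated times of 45 min and 30 min (on this read-out lower numbers stand for stronger inhibition and higher numbers for weaker inhibition), compound 1 gives > 63000 nM, which is a limit of the assay rather than a number.
Compound 2, `O=S(=O)(Nc1ccc(-c2nc3ccccc3o2)cc1)c1cccc(C(F)(F)F)c1`. In this assay compound 2 gives > 63000 nM, again a limit of the assay.
Compound 3, `O=S(=O)(Nc1ccc2oc(-c3ccccc3)nc2c1)c1ccc(C(F)(F)F)cc1`. In this assay compound 3 gives > 63000 nM, once more a limit of the assay.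

Compound 1 therefore stands nowhere on a scale of numbers: its result is only a limit, and the two other measured compounds sit at the same limit, as summed up by the limit of > 63000 nM in this assay, at which 3 of the 3 values shown sit. For the measured compounds named here, the only step between measured compounds, a step that the two limits leave unreadable from compound 1 to compound 2, cannot be read, since both ends are limits. Nothing measured shows a change of any readable size.

Compound 4, `COc1ccc(Cl)cc1S(=O)(=O)Nc1ccc(-c2nc3ccccc3o2)cc1`, is the compound still to be tested. It differs from compound 1 by methoxy in place of hydrogen on an aromatic carbon. Going by the values given here, no measured step bears on this change, so no direction can be taken from the data; the one reading available for compound 1 is a limit.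

Given that every compound so far sits at the limit, compound 4 is expected to remain at it, with an estimated step that the limit leaves unreadable from compound 1 to compound 4 in this assay. The estimate for compound 4 in this assay is 100000 nM, with an expected range from 30000 nM to 400000 nM.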

Compound 4, half-maximal inhibitory concentration: > 63000 nM
Compound 4: a limit, no number; the forecaster's own chance of this, stated with the estimate: 85%; the middle value lies beyond the limit too.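

Compound 4, like compound 1, gives only a limit of the assay and not a number, so the step between compound 1 and compound 4 cannot be read. The compounds shown leave open how strongly any of them inhibits the enzyme, and whether adding the methoxy group changes that at all, because all of them stop at one value: the limit of > 63000 nM in this assay, at which 4 of the 4 values shown sit.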